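The compounds below may be only part of what the source reports. "The series", "measured", "known", "first", "only" and "open" are said of these compounds alone.

Two measured compounds frame this step. Compound 1, `Cc1cc(C)cc(-n2nncc2CN2C(=O)C3(C(C#N)=C(N)Oc4c3c3nc5ccccc5nc3c3ccccc43)c3ccccc32)c1`, and compound 2, `Cc1ccccc1-n1nncc1CN1C(=O)C2(C(C#N)=C(N)Oc3c(N)cc4nc5ccccc5nc4c32)c2ccccc21`, carry the shared core and differ from each other in more than one place. In an ADME assay on HUVEC cells (Homo sapiens) for antiproliferative activity, read by MTT assay, with a stated time of 48 h (a lower number here means a stronger inhibitor, a higher number a weaker inhibitor), compound 1 reaches only a limit of the assay, > 50000 nM. In this assay compound 2 likewise reaches only a limit, > 50000 nM. Compound 2 therefore stands at the limit rather than at a number, and it shares that position with the other value shown (the limit of > 50000 nM in this assay, at which 2 of the 2 values shown sit). The compound not yet measured is compound 3, `N#CC1=C(N)Oc2c(N)cc3nc4ccccc4nc3c2C12C(=O)N(Cc1cnnn1-c1cccc(Br)c1)c1ccccc12`. It differs from compound 2 in one place: 3-bromophenyl in place of 2-methylphenyl on an aromatic nitrogen. Among the compounds with values here, no step between measured compounds is available, so the size of this change in this assay cannot be read from a neighbouring pair. The expectation for compound 3 is that it stays at the limit of this assay, the step that the limit leaves unreadable from compound 2 to compound 3 being expected to amount to nothing beyond the scatter, because the limit of > 50000 nM in this assay, at which 2 of the 2 values shown sit, holds both values shown. The estimate for compound 3 in this assay is 80000 nM, expected to lie between 30000 nM and 300000 nM.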

Compound 3, half-maximal inhibitory concentration: > 50000 nM
Compound 3 was reported as a limit; the forecaster's own chance of this, stated with the estimate: 80%; the middle value does not contradict the limit.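

In this assay compound 3 gives > 50000 nM, which is a limit of the assay and not a number. No step can be read between compound 2 and compound 3, and the values shown all stand at one limit: the limit of > 50000 nM in this assay, at which 3 of the 3 values shown sit. The compounds shown leave open what size, if any, the change from 2-methylphenyl to 3-bromophenyl has in this assay; none of them gives a number there.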